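Sulfone Versus Sulfide in a Bromophenyl Enone Series

The compounds below may be only part of what the source reports. "The series", "measured", "known", "first", "only" and "open" are said of these compounds alone.

Compound 1 `O=C(/C(=C\c1c[nH]c2ccccc12)Sc1ccc(Br)cc1)c1ccc(Br)cc1`: 1000 nM
Compound 2 `O=C(/C(=C\c1ccc(F)cc1Cl)Sc1ccc(Br)cc1)c1ccc(Br)cc1`: 1000 nM
Compound 3 `O=C(/C(=C\c1c[nH]c2ccccc12)S(=O)(=O)c1ccc(Br)cc1)c1ccc(Br)cc1`: 25000 nM

These three compounds were tested in a functional assay on DU-145 cells (Homo sapiens) for inhibition, read by trypan blue exclusion, with a stated time of 96 h; a lower number here means a stronger inhibitor of growth, a higher number a weaker inhibitor of growth. Compound 1 and compound 2 share one core, while compound 3 and the still unmeasured compound 4 `O=C(/C(=C\c1ccc(F)cc1Cl)S(=O)(=O)c1ccc(Br)cc1)c1ccc(Br)cc1` share another. The two cores differ by (4-bromophenyl)sulfonyl in place of (4-bromophenyl)sulfanyl on a double-bonded chain carbon bound to a carbonyl carbon and a double-bonded chain carbon. That difference alone produced a 25-fold higher number from compound 1 to compound 3 (1.40 log units; beyond the scatter), the largest movement seen here.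

Within the first core, compound 2 differs from compound 1 by 2-chloro-4-fluorophenyl in place of 1H-indol-3-yl on a double-bonded chain carbon bound to a double-bonded chain carbon, and this gave no change at the digits printed from compound 1 to compound 2 (within the scatter). Compound 4 differs from compound 3 by 2-chloro-4-fluorophenyl in place of 1H-indol-3-yl on a double-bonded chain carbon bound to a double-bonded chain carbon. The place is described in identical words for both pairs, so this is the same change made once more, now on the core of compound 3.

The step for compound 4 in this assay is expected to be no change at the digits printed from compound 3 to compound 4 (within the scatter). That expectation rests on compound 2, whose step from compound 1 was no change at the digits printed from compound 1 to compound 2 (within the scatter). In this assay compound 4 is therefore estimated at 25000 nM, most likely within a range from 10000 nM to 60000 nM. For the measured compounds named here, only one prior example supports this, so the range is kept wide.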

Compound 4, concentration for 50% growth inhibition: 50000 nM
Compound 4: middle estimate off by 2.0-fold (0.30 log units), on the low side; low and high end bracket the measured number.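

In this assay, putting 2-chloro-4-fluorophenyl in place of 1H-indol-3-yl on the core of compound 3 gave a 2.0-fold higher number from compound 3 to compound 4 (0.30 log units; within the scatter). Set beside the same change on the core of compound 1, the two results cannot be told apart: the same change on two cores in this assay, no change at the digits printed (within the scatter) from compound 1 to compound 2 and a 2.0-fold higher number (0.30 log units; within the scatter) from compound 3 to compound 4, 2.0-fold (0.30 log units) apart, within the scatter of two such steps This shows that, for these two pairs, the change carried from one core to the other without a detectable difference, and that the large gap between the two cores remained the main feature of the data, but two pairs in a single assay cannot show that this would hold on any further core or in any other test, and they give no reason for the result.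

The compounds shown leave open what other groups at this place would do, such as an amine or a carboxylic acid attached to the phenyl ring in place of the chlorine. They also leave open whether the same result would hold if a methoxy group replaced the bromine on either 4-bromophenyl group.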